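A Pyrrole Ring in Place of a Chlorinated Phenyl Ring

This account rests on a few compounds, and the source may have more. Where it says the series, first, only, none or still open, it means among the compounds named here.

Compound 3 `CC1=CC[C@H](C(C)(C)NC(=S)N/N=C/c2cccc(Cl)c2)CC1` carries a 3-chlorophenyl group on the carbon that is double-bonded to nitrogen. In an ADME assay on Vero cells (Chlorocebus sabaeus) for inhibition, read by sulforhodamine B assay, with a stated time of 48 h (on this read-out higher numbers stand for weaker inhibition of growth and lower numbers for stronger inhibition of growth), compound 3 reaches only the limit of the measurement, giving > 100000 nM. Compound 1 `CC1=CC[C@H](C(C)(C)NC(=S)N/N=C/c2ccccc2)CC1`, which bears a plain phenyl ring in the same place, likewise reaches only a limit; in this assay compound 1 gives > 100000 nM. Two of the three values thus sit at the limit of > 100000 nM in this assay, at which 2 of the 3 values shown sit. For the measured compounds named here, compound 2 `CC1=CC[C@H](C(C)(C)NC(=S)N/N=C/c2ccccc2O)CC1`, whose ring carries a hydroxy group, is the one compound with a true number: in this assay compound 2 gives 11200 nM. The step that the two limits leave unreadable from compound 1 to compound 3 cannot be sized. The steps of an at least 8.9-fold lower number from compound 1 to compound 2 (0.95 log units; beyond the scatter) and an at least 8.9-fold higher number from compound 2 to compound 3 (0.95 log units; beyond the scatter) show that, among these three, only the hydroxy-bearing compound 2 gives a number.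

Compound 4 `CC1=CC[C@H](C(C)(C)NC(=S)N/N=C/c2ccc[nH]2)CC1` differs from compound 3 by 1H-pyrrol-2-yl in place of 3-chlorophenyl on a carbon with a double bond to nitrogen. Going by the values given here, the incoming ring brings one hydrogen-bond donor, as the hydroxy group of compound 2 does, but no measured step covers a five-membered ring. For compound 4 the expected step is an at least 1.4-fold lower number from compound 3 to compound 4 (0.15 log units; that floor lies within the scatter), which means a number near or at the limit. Compound 4 is therefore estimated at 70000 nM, expected to fall between 15000 nM and 300000 nM.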

Compound 4, concentration for total growth inhibition: > 100000 nM
Compound 4: no number, only a limit (the forecaster's own chance of this, stated with the estimate: 55%); at least 1.4-fold (0.15 log units) between middle value and limit.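

At this position, on a carbon with a double bond to nitrogen, a hydrogen-bond donor in the incoming ring does not by itself yield a true number in this assay: the 1H-pyrrol-2-yl group carries one, yet compound 4 gives only a limit, > 100000 nM. Putting 1H-pyrrol-2-yl in place of 2-hydroxyphenyl gives an at least 8.9-fold higher number from compound 2 to compound 4 (0.95 log units; beyond the scatter), so the only true number among the compounds shown still belongs to the ring with the hydroxy group. The steps that join one limit to another cannot be read, and the set now gathers at a single limit: the limit of > 100000 nM in this assay, at which 3 of the 4 values shown sit.

The compounds shown leave open whether the true number of compound 2 depends on the hydroxy group itself or on that group being carried by a phenyl ring. A phenyl ring bearing an amine or a methoxy group in place of the hydroxy group would help to separate these two readings.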